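The source may report more compounds than this note shows. Statements on the series, on what has been measured and on what is new or still open speak of the compounds shown alone.

Measured compounds:
compound 1 `COc1cc(N)c(Cl)cc1C(=O)NC1CCN(CCCCCCCCO)CC1` — 15.9 nM
compound 2 `COc1cc(N)c(Cl)cc1C(=O)NC1CCN(CCN2CCCCC2)CC1` — 100 nM

In a functional assay on HEK293 cells for agonist activity at 5-hydroxytryptamine receptor 4 (Homo sapiens), read by cAMP accumulation (a lower number here means that less compound is needed, a higher number that more compound is needed for the effect), compound 1 gives 15.9 nM, the lowest of the two numbers shown; the nearest is compound 2, and the step of a 6.3-fold higher number from compound 1 to compound 2 (0.80 log units; beyond the scatter) lies beyond the scatter. That step exchanges the whole 6-hydroxyhexyl arm for a piperidin-1-yl group two bonds along the chain from the ring amine nitrogen, so chain length and terminal group change together.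

Compound 3 `COc1cc(N)c(Cl)cc1C(=O)NC1CCN(CCCCCCCCN2CCCCC2)CC1` differs from compound 1 by piperidin-1-yl in place of hydroxy on a saturated chain carbon, eight bonds along the chain from an amine nitrogen in a ring. Here the chain is kept at its full length and only the terminal hydroxy is exchanged for piperidin-1-yl. Within the data shown here, the only measured step that bears on this, a 6.3-fold higher number from compound 1 to compound 2 (0.80 log units; beyond the scatter), mixes in the loss of the chain, so it sets at most a loose upper bound on what a terminal amine ring alone does. A smaller movement in this assay, in the same direction, is therefore expected, roughly a 2.0-fold higher number from compound 1 to compound 3 (0.30 log units; within the scatter).

The estimate for compound 3 in this assay is 32 nM, with a range from 8 nM to 130 nM.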

Compound 3, half-maximal effective concentration: 3.16 nM
Beside the measured number, compound 3's estimate is 10-fold (1.01 log units) above it, outside the stated range (below it).
By their numbers in this assay, from the lowest: compound 3; then compound 1; then compound 2.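

With the chain kept at its full length, piperidin-1-yl in place of hydroxy, eight bonds along the chain from an amine nitrogen in a ring, gives a 5.0-fold lower number from compound 1 to compound 3 (0.70 log units; beyond the scatter) in this assay. This step runs opposite to a 6.3-fold higher number from compound 1 to compound 2 (0.80 log units; beyond the scatter), so a terminal piperidin-1-yl does not by itself carry a penalty at this position, and at the end of this long chain the exchange lowers the number needed for the effect. No measured evidence is at hand that would account for this change.

What remains open is how much of the step depends on the chain, since the compounds shown do not say whether piperidin-1-yl would give a similar result on a chain of intermediate length or on a longer chain. They also leave open whether the result is particular to piperidin-1-yl or extends to other terminal groups, such as a morpholin-4-yl ring, a dimethylamino group or a carboxylic acid, at the same place on the chain.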